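The source may hold more compounds than are shown below. What is called first, only, known or untested is meant among the compounds shown, and "the series" means these compounds.

Working notes on the series. In a functional assay on NCI-H460 cells (Homo sapiens) for inhibition, read by MTT assay, with a stated time of 72 h (on this read-out lower numbers stand for stronger inhibition and higher numbers for weaker inhibition), compound 1 `COc1cc2c(Oc3ccc(NC(=O)c4nn(-c5ccccc5)c(=O)cc4C)cc3F)ccnc2cc1OCCCN1CCN(C)CC1` gives 360 nM. Among the measured compounds shown here, compound 2 `COc1cc2c(Oc3ccc(NC(=O)c4nn(-c5ccccc5C(F)(F)F)c(=O)cc4C)cc3F)ccnc2cc1OCCCN1CCN(C)CC1` gives 240 nM in this assay; the only single-point step measured so far is a 1.5-fold lower number from compound 1 to compound 2 (0.18 log units; within the scatter). Compound 3 `COc1cc2c(Oc3ccc(NC(=O)c4nn(-c5cccc(F)c5)c(=O)cc4C)cc3F)ccnc2cc1OCCCN1CCC(C)CC1` gives 250 nM in this assay. On the numbers shown, compound 3 has compound 2 as its nearest neighbour and compound 1 as its furthest, yet each of those gaps falls within the scatter, so no ordering of compound 1, compound 2 and compound 3 can be read from them.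

Compound 4 `COc1cc2c(Oc3ccc(NC(=O)c4nn(-c5cccc(F)c5)c(=O)cc4C)cc3F)ccnc2cc1OCCCN1CCN(C)CC1` is not yet measured. It differs from compound 3 by 4-methylpiperazin-1-yl in place of 4-methylpiperidin-1-yl on a saturated chain carbon, three bonds along the chain from an oxygen on an aromatic ring. For the measured compounds named here, no measured pair differs in this place alone: compound 1 and compound 2 carry the 4-methylpiperazin-1-yl and compound 3 the 4-methylpiperidin-1-yl, but these compounds also differ elsewhere, so their values show only that both chain ends sit at comparable numbers. Going by the values given here, the one measured step concerns another position and offers no direct guide here. The expected step is therefore a 1.0-fold higher number from compound 3 to compound 4 (0.02 log units; within the scatter), nothing beyond the scatter. For compound 4 the estimate in this assay is 260 nM, with a range from 120 nM to 550 nM.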

Compound 4, half-maximal inhibitory concentration: 260 nM
Estimate against measurement, compound 4: no gap at the digits printed, and the stated range covers the measured number.
By their numbers in this assay, from the lowest: compounds 2, 3, 4 and 1 (each within the scatter of the next).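

Among the compounds shown here, compound 3 and compound 4 form the first pair in this assay that differs at this position alone: 4-methylpiperazin-1-yl in place of 4-methylpiperidin-1-yl gives a 1.0-fold higher number from compound 3 to compound 4 (0.02 log units; within the scatter), so with the 3-fluorophenyl group held constant these two chain ends cannot be told apart, which compound 1, compound 2 and compound 3 could not show. Compound 4 also adds to the picture on the aromatic nitrogen, where fluoro in place of hydrogen on an aromatic carbon gives a 1.4-fold lower number from compound 1 to compound 4 (0.14 log units; within the scatter) and 3-fluorophenyl in place of 2-(trifluoromethyl)phenyl gives a 1.1-fold higher number from compound 2 to compound 4 (0.03 log units; within the scatter), leaving all three of these aryl groups within the scatter of one another. No evidence is available that would explain these results.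

Going by these compounds, whether the two chain ends also remain indistinguishable with another group on the aromatic nitrogen stays open, as the direct comparison rests on one pair. The compounds shown also do not tell whether a morpholin-4-yl or dimethylamino group at the chain end, or a longer chain than the propyl link, would give a number beyond the scatter.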